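The compounds below may be only part of what the source reports. "The series", "measured", "known", "first", "only" and "open" are said of these compounds alone.

In an ADME assay on MCF7 cells (Homo sapiens) for cytotoxicity, with a stated time of 72 h (a higher number here means a weaker inhibitor, a lower number a stronger inhibitor), compound 1 `COc1cccc(CNc2ncnc3c2ncn3C2CCCCO2)c1` gives 97000 nM, while compound 2 `COc1ccc(OC)c(CNc2ncnc3c2ncn3C2CCCCO2)c1` gives 25400 nM, the lower of the two numbers. Compound 3 `COc1ccc(OC)c(CNc2ncnc3c2ncn3C2CCCO2)c1` differs from compound 2 by oxolan-2-yl in place of oxan-2-yl on an aromatic nitrogen, with oxolan-2-yl in place of oxan-2-yl on an aromatic nitrogen. Within the data shown here, the only measured step, a 3.8-fold lower number from compound 1 to compound 2 (0.58 log units; beyond the scatter), comes from methoxy in place of hydrogen on an aromatic carbon, so it gives only a rough sense of scale and does not test this change. The expected result is therefore no step beyond the scatter, with an estimated 1.2-fold higher number from compound 2 to compound 3 (0.07 log units; within the scatter). The estimate for compound 3 is 30000 nM, with an expected range of 12000 nM to 70000 nM.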

Compound 3, half-maximal inhibitory concentration: > 50000 nM
Compound 3: only a limit was reported; the forecaster's own chance of this, stated with the estimate: 10%; middle value at least 1.6-fold (0.22 log units) from the limit.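

For compound 3, the > 50000 nM in this assay is a limit and not a number: the limit of > 50000 nM in this assay, at which 1 of the 3 values shown sits. Among these compounds, the earlier compounds both carried oxan-2-yl on the aromatic nitrogen, and oxolan-2-yl there gives an at least 1.9-fold higher number from compound 2 to compound 3 (0.29 log units; that floor lies within the scatter), the first reading at this position. Because that floor comes from the limit, the step shows no change beyond the scatter, yet it does not rule one out: the limit of > 50000 nM in this assay, at which 1 of the 3 values shown sits. From the compounds shown here alone, how far compound 3 truly lies from compound 2 remains open. So does whether an ethyl chain or a piperidine ring on that nitrogen would lower the number.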